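Swapping the benzamide ring on a piperidine sulfonamide core

The source may report more compounds than this note shows. Statements on the series, on what has been measured and on what is new or still open speak of the compounds shown alone.

Measured compounds:
- compound 1, `COC(=O)c1cccc(C(=O)N2CCC(N(C3CC3)S(=O)(=O)c3cccc(C(F)(F)F)c3)CC2)c1`: "not determined" (no result reported)
- compound 2, `O=C(c1ccccc1)N1CCC(N(C2CC2)S(=O)(=O)c2cccc(C(F)(F)F)c2)CC1`: "not determined" (no result reported)
- compound 3, `O=C(c1cccc(OC(F)(F)F)c1)N1CCC(N(C2CC2)S(=O)(=O)c2cccc(C(F)(F)F)c2)CC1`: 60%

The three compounds share one core, a piperidine bearing a cyclopropyl sulfonamide with a trifluoromethylphenyl group, and differ only in the aryl group on the carbonyl carbon. In an assay on cells for inhibition of Voltage-dependent L-type calcium channel subunit alpha-1C (Homo sapiens), read by FLIPR and calcium flux, tested at 1 uM (on this read-out lower numbers stand for a weaker effect and higher numbers for a stronger effect at the one concentration tested), compound 1 has no result, so it stands nowhere on the numbers shown; compound 2 is in the same position. Compound 3, which also carries a trifluoromethoxy-substituted phenyl on the carbonyl carbon, gives 60% in this assay and is the only anchor available.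

Compound 4, `O=C(c1ccc(OC(F)(F)F)cc1)N1CCC(N(C2CC2)S(=O)(=O)c2cccc(C(F)(F)F)c2)CC1`, is the next compound to be measured. It differs from compound 1 by 4-(trifluoromethoxy)phenyl in place of 3-(methoxycarbonyl)phenyl on a carbonyl carbon. Going by the values given here, with no value for compound 1, no step can be computed for this pair; the nearest reference is compound 3, whose aryl group is a trifluoromethoxyphenyl as in compound 4.

Among the compounds with values here, compound 4 is therefore expected to give a result in this assay near that of compound 3, with an estimate of 50% and a range from 20% to 80%, where the width reflects that only one measured neighbour exists and the change itself is untested.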

Compound 4, a percentage reported as inhibition, at one concentration (the size of the read-out at that concentration, not a potency): 73%
Compound 4: middle estimate off by 23 percentage points, on the low side, within the range that was stated.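

Going by these compounds alone, the two trifluoromethoxy compounds form the first readable pair at this place: with 4-(trifluoromethoxy)phenyl in place of 3-(trifluoromethoxy)phenyl on a carbonyl carbon, this assay shows a number 13 percentage points higher from compound 3 to compound 4 (beyond the scatter). The read-out at this place is therefore sensitive to where the trifluoromethoxy group stands on the phenyl ring, although this rests on a single modest step at one concentration and says nothing about potency. Nothing in the data shown offers an explanation for this difference.

Steps involving compound 1 or compound 2 cannot be read, so how the 3-(methoxycarbonyl)phenyl group or the plain phenyl group compares with either trifluoromethoxy-substituted ring remains unknown. Also open, going by these compounds, is what a carboxylic acid, an amine or a nitrile at the same ring positions would give, and whether the preference seen between compound 3 and compound 4 would hold for any group other than trifluoromethoxy.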